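Benzyl ring changes in the series: notes towards compound 4

The source may hold more compounds than are shown below. What is called first, only, known or untested is meant among the compounds shown, and "the series" means these compounds.

Measured in a functional assay on K562 cells (Homo sapiens) for antiproliferative activity, with a stated time of 72 h; on this read-out lower numbers stand for stronger inhibition and higher numbers for weaker inhibition:
- compound 1 `OC[C@H]1O[C@@H](n2cnc3c(NCc4ccc(Cl)cc4Cl)ncnc32)[C@H](O)[C@@H]1O`: 106000 nM
- compound 2 `OC[C@H]1O[C@@H](n2cnc3c(NCc4ccc(Cl)c(Cl)c4)ncnc32)[C@H](O)[C@@H]1O`: 10800 nM
- compound 3 `COc1ccc(CNc2ncnc3c2ncn3[C@@H]2O[C@H](CO)[C@@H](O)[C@H]2O)c(OC)c1`: > 166000 nM (a limit, not a number)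

Compound 3 has no measured number and stands at the limit of > 166000 nM in this assay, at which 1 of the 3 values shown sits. Compound 4 `OC[C@H]1O[C@@H](n2cnc3c(NCc4ccc(F)cc4F)ncnc32)[C@H](O)[C@@H]1O` differs from it as follows: 2,4-difluorophenyl in place of 2,4-dimethoxyphenyl on a saturated chain carbon bound to a nitrogen on an aromatic ring. In words, this is 2,4-difluorophenyl in place of 2,4-dimethoxyphenyl on a saturated chain carbon bound to a nitrogen on an aromatic ring.

The closest measured comparison is an at least 1.5-fold higher number from compound 1 to compound 3 (0.19 log units; that floor lies within the scatter), which also exchanges a 2,4-dimethoxyphenyl for a dihalogenated group. Its floor does not separate the pair. The clearer steps, a 9.8-fold lower number from compound 1 to compound 2 (0.99 log units; beyond the scatter) and an at least 15-fold higher number from compound 2 to compound 3 (1.18 log units; beyond the scatter), both involve 3,4-dichlorophenyl, which compound 4 lacks, so they carry little weight here. Among the measured compounds shown here, no fluorinated compound has been measured. In this assay, a small move to a lower number is therefore expected, and it may stay within the scatter. The expected step is an at least 1.5-fold lower number from compound 3 to compound 4 (0.17 log units; that floor lies within the scatter). Compound 4 is estimated at 110000 nM, with an expected range of 40000 nM to 250000 nM.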

Compound 4, half-maximal inhibitory concentration: 9600 nM
Compound 4: middle estimate off by 11-fold (1.06 log units), on the high side, and the stated range ends above it.
By their numbers in this assay, from the lowest: compounds 4 and 2 (each within the scatter of the next); then compound 1. At a limit, above all of these: compound 3.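

In this assay, a 2,4-difluorophenyl on this saturated chain carbon does not share the weak numbers of the other two 2,4-disubstituted groups, so the substitution pattern alone does not set the level: in place of 2,4-dichlorophenyl it gives an 11-fold lower number from compound 1 to compound 4 (1.04 log units; beyond the scatter). Among the compounds shown here, in place of 3,4-dichlorophenyl it gives a 1.1-fold lower number from compound 2 to compound 4 (0.05 log units; within the scatter), so the two groups cannot be told apart here, and 3,4-dichlorophenyl is no longer the only group on this carbon with a number near this level. In place of 2,4-dimethoxyphenyl it gives an at least 17-fold lower number from compound 3 to compound 4 (1.23 log units; beyond the scatter); that step is only a floor, set by a limit: the limit of > 166000 nM in this assay, at which 1 of the 4 values shown sits.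

On these data alone, what a plain phenyl or a 3,4-difluorophenyl would give at this place remains open. So does the effect of a longer chain between the ring and the nitrogen.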